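Swapping dimethoxyphenyl for indolyl in compound 3

A few compounds are considered here, and "the series" means these few. Any claim that something is new, unique, unknown or untested is made for them only; others in the source may bear on it.

Compound 1 `COc1ccc(-c2nc3ccccn3c2C(=O)/C=C\Nc2ccc3[nH]ccc3c2)cc1`: 18900 nM
Compound 2 `COc1cc(N/C=C\C(=O)c2c(-c3ccc(Cl)cc3)nc3ccccn23)cc(OC)c1OC`: 3390 nM
Compound 3 `COc1cc(N/C=C\C(=O)c2c(-c3ccc(Cl)cc3)nc3ccccn23)cc(OC)c1`: 13600 nM

These values come from a functional assay on MCF7 cells (Homo sapiens) for cytotoxicity, read by MTT assay, with a stated time of 48 h (on this read-out higher numbers stand for weaker inhibition and lower numbers for stronger inhibition), and a lower number means stronger inhibition. Compound 3 (13600 nM) lies within the usual scatter of compound 1, and its number is higher than that of compound 2. The measured step is a 4.0-fold higher number from compound 2 to compound 3 (0.60 log units; beyond the scatter) and it is modest but beyond the scatter. Compound 4 `O=C(/C=C\Nc1ccc2[nH]ccc2c1)c1c(-c2ccc(Cl)cc2)nc2ccccn12` has 1H-indol-5-yl in place of 3,5-dimethoxyphenyl on an amine nitrogen. That measured step is a different change, so it only shows that this group can move the number. Compound 1 carries the same 1H-indol-5-yl, but its core differs from that of compound 4. Among the compounds with values here, no measured step tests this swap directly, so no clear shift is expected. The estimated step is a 1.1-fold lower number from compound 3 to compound 4 (0.05 log units; within the scatter) in this assay and it is expected to stay within the scatter. For compound 4 the estimated value is 12000 nM with an expected range from 4000 nM to 35000 nM in this test.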

Compound 4, half-maximal inhibitory concentration: 7130 nM
Compound 4: the middle estimate sits 1.7-fold (0.23 log units) above what was measured; the range from low to high includes it.
By their numbers in this assay, from the lowest: compound 2; then compounds 4, 3 and 1 (each within the scatter of the next, the first and the last beyond it).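

In this assay, 1H-indol-5-yl in place of 3,5-dimethoxyphenyl on an amine nitrogen gives a 1.9-fold lower number from compound 3 to compound 4 (0.28 log units; within the scatter), so these two groups cannot be told apart at this position. With 1H-indol-5-yl held fixed, chloro in place of methoxy on an aromatic carbon gives a 2.7-fold lower number from compound 1 to compound 4 (0.42 log units; beyond the scatter), so this second change does move the number. No available measurement explains either step. From the compounds shown here alone, it remains open whether a pyridinyl group on the amine nitrogen would also stay within the scatter of these two groups. Going by these compounds, it also remains open how fluoro or trifluoromethyl would compare with chloro.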